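A few compounds are considered here, and "the series" means these few. Any claim that something is new, unique, unknown or untested is made for them only; others in the source may bear on it.

Three compounds of the series carry a measured value in a physicochemical assay for lipophilicity; a lower number here means a more polar compound, a higher number a more lipophilic compound. Compound 1 `O=S(=O)(Nc1ccncn1)c1ccc2c(c1)OCC[C@@H]2c1ccc(C(F)(F)F)cc1-c1ccc(F)cn1` gives 3, compound 3 `O=S(=O)(Nc1nccs1)c1ccc2c(c1)OCC[C@@H]2c1ccc(C(F)(F)F)cc1N1CCNCC1` gives 1.4, and compound 2 `Cn1nccc1-c1cc(C(F)(F)F)ccc1[C@H]1CCc2cc(S(=O)(=O)Nc3ncccn3)ccc21` gives 2.4. Compound 2 stands second highest of the three: compound 1 lies a step higher that is beyond the scatter, while compound 3 lies a larger step lower, also beyond the scatter. Compound 4 `Cc1ccc(-c2cc(C(F)(F)F)ccc2[C@H]2CCc3cc(S(=O)(=O)Nc4ncccn4)ccc32)cn1` is not yet measured. It differs from compound 2 in one place: 6-methylpyridin-3-yl in place of 1-methyl-1H-pyrazol-5-yl on an aromatic carbon. Among the compounds with values here, no measured pair separated by this change exists in this assay, so the size of the step is open. A step upward beyond the scatter is expected, namely a number 0.70 log units higher from compound 2 to compound 4 (beyond the scatter). Compound 4 is therefore estimated at 3.1, within a range from 2.7 to 3.6.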

Compound 4, distribution coefficient: 2.8
Beside the measured number, compound 4's estimate is 0.30 log units above it, within the range that was stated.
By their numbers in this assay, from the lowest: compound 3; then compound 2; then compounds 4 and 1 (each within the scatter of the next).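

In this assay, the aromatic carbon ortho to a large group and meta to a trifluoromethyl group now has its first one-place comparison: 6-methylpyridin-3-yl in place of 1-methyl-1H-pyrazol-5-yl gives a number 0.40 log units higher from compound 2 to compound 4 (beyond the scatter) on the shared core. The position therefore responds to this change of aromatic ring by a modest step. From the compounds shown here alone, what a carboxylic acid or a primary amine on this carbon would give in this assay stays open. Nothing at hand bears on what lies behind the step.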